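The source may hold more compounds than are shown below. What is called first, only, known or untested is meant among the compounds shown, and "the series" means these compounds.

Of the compounds shown here, two carry numbers so far. Compound 1 `O=C(Nc1nnc(-c2ccc(O)c(O)c2)s1)c1ccc(Cl)cc1` is one; in a functional assay on A549 cells (Homo sapiens) for cytotoxicity, read by MTT assay, with a stated time of 72 h (on this read-out higher numbers stand for weaker inhibition and lower numbers for stronger inhibition), compound 1 gives 14600 nM. Compound 2 `CC(=O)Nc1nnc(-c2cccc(O)c2O)s1` is the other; in this assay compound 2 gives 200000 nM. Compound 1 thus holds the lower of the two numbers, and its gap to compound 2 lies beyond the usual scatter. The two differ in more than one place, so no single change can be read from that pair.

Compound 3 `O=C(Nc1nnc(-c2ccc(O)c(O)c2)s1)c1ccccc1` is not yet measured. It differs from compound 1 in one place: hydrogen in place of chloro on an aromatic carbon. Among the measured compounds shown here, nothing measured so far bears on this change on its own, and the two numbers in hand do not show what a substituent at this position contributes. The step is therefore expected to be modest, with the number for compound 3 drifting somewhat upward, near the edge of the scatter, which corresponds to an expected 1.7-fold higher number from compound 1 to compound 3 (0.23 log units; within the scatter). Compound 3 is accordingly estimated at 25000 nM, with a range from 10000 nM to 70000 nM.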

Compound 3, half-maximal inhibitory concentration: 13000 nM
Estimate against measurement, compound 3: 1.9-fold (0.28 log units) above; the measured number falls inside the stated range.
By their numbers in this assay, from the lowest: compounds 3 and 1 (each within the scatter of the next); then compound 2.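

In this assay, hydrogen in place of chloro on an aromatic carbon, para to a large group, gives a 1.1-fold lower number from compound 1 to compound 3 (0.05 log units; within the scatter), so the two compounds cannot be told apart on this read-out. Among the compounds shown here, this is the first single-place reading, and it shows that, on the core of compound 1, the chloro is not required for a number at this level: the change from 4-chlorophenyl to phenyl leaves no visible mark. No measurement at hand speaks to the reason for this result.

On these data alone, only chloro and hydrogen are compared at this position, so it remains open whether a larger or differently built group there, such as an amine, a carboxylic acid or a methoxy group, would move the number beyond the scatter. Also open, as far as these compounds go, is what the other parts of the molecule contribute on their own, since compound 2 differs from the others in more than one place and the effects of its acetyl group and of the placement of its hydroxy groups cannot be separated.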